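Swapping the sulfonyl substituent in an acyl sulfonamide series

A few compounds are considered here, and "the series" means these few. Any claim that something is new, unique, unknown or untested is made for them only; others in the source may bear on it.

Among the compounds with values here, compound 2 `CNC(=O)NCCS(=O)(=O)NC(=O)c1ccc(Nc2nc(NC3(c4ccc(Cl)cc4)CC3)nc(OCC(F)(F)F)n2)cc1` has the higher of the two numbers measured so far in a physicochemical assay for permeability, using PAMPA, at pH 7.4 (on this read-out lower numbers stand for lower permeability and higher numbers for higher permeability), giving 40 nm/s; compound 1 `CC(C)S(=O)(=O)NC(=O)c1ccc(Nc2nc(NC3(c4ccc(Cl)cc4)CC3)nc(OCC(F)(F)F)n2)cc1` gives 31 nm/s in this assay, and the step of a 1.3-fold higher number from compound 1 to compound 2 (0.11 log units; within the scatter) is small. Compound 3 `O=C(NS(=O)(=O)c1ccc(F)cc1)c1ccc(Nc2nc(NC3(c4ccc(Cl)cc4)CC3)nc(OCC(F)(F)F)n2)cc1` differs from compound 2 by 4-fluorophenyl in place of 2-((methylcarbamoyl)amino)ethyl on a sulfonyl sulfur. Within the data shown here, only that one step bears on the change, and it stayed within the scatter, so for compound 3 a step of a 1.4-fold higher number from compound 2 to compound 3 (0.14 log units; within the scatter) that may not exceed the scatter is expected in this assay. Compound 3 is therefore estimated at 55 nm/s, within the range 25 nm/s to 130 nm/s.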

Compound 3, apparent permeability: 193 nm/s
Compound 3: middle estimate off by 3.5-fold (0.55 log units), on the low side; measured number above the stated range.
By their numbers in this assay, from the lowest: compounds 1 and 2 (each within the scatter of the next); then compound 3.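

On the sulfonyl sulfur, the substituent can move the number in this assay beyond the scatter: 4-fluorophenyl gives a 4.8-fold higher number from compound 2 to compound 3 (0.68 log units; beyond the scatter) and a 6.2-fold higher number from compound 1 to compound 3 (0.79 log units; beyond the scatter). The two substituents compared earlier, isopropyl and 2-((methylcarbamoyl)amino)ethyl, had stayed within the scatter of each other, so this position is not as indifferent as that pair suggested. Nothing measured here explains the rise.

On these data alone, whether it follows from the aromatic ring or from its fluorine stays open. A plain phenyl, a pyridine ring or a 4-methoxyphenyl group on the same sulfur would separate these.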